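Quinoline ketone series: cyano to amino on the fused ring

The source may report more compounds than this note shows. Statements on the series, on what has been measured and on what is new or still open speak of the compounds shown alone.

Measured compounds:
- compound 1, `CN(c1ccc(F)c(O)c1)c1cccc(-c2cccc(O)c2F)n1`, an assay for inhibition of 17-beta-hydroxysteroid dehydrogenase type 1 (Homo sapiens), read by HPLC, with a stated time of 10 min, tested at 1 uM; on this read-out lower numbers stand for less inhibition and higher numbers for more inhibition at the one concentration tested (going by the name of the read-out): 99%
- compound 2, `N#Cc1ccc2ccc(C(=O)c3ccc(F)c(O)c3)nc2c1`, this assay: "not active" (no number reported)
- compound 3, `Oc1cc(Nc2cccc(-c3cccc(O)c3F)n2)ccc1F`, this assay: 57%

Going by the values given here, compound 1 and compound 3 share a core and differ by hydrogen in place of methyl on a nitrogen on an aromatic ring; the step of a number 42 percentage points lower from compound 1 to compound 3 (beyond the scatter) is the only measured step in the set. Compound 2 has a different core and gives no single number in this assay: the read-out for compound 2 is reported only as "not active" (no number reported), so it stands below whatever the assay resolves, with no place among the numbers of compound 1 and compound 3.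

Compound 4, `Nc1ccc2ccc(C(=O)c3ccc(F)c(O)c3)nc2c1`, has yet to be measured in this assay. It differs from compound 2 by amino in place of cyano on an aromatic carbon. Among the compounds with values here, no measured step concerns this change or this core; the step from compound 1 to compound 3 touches a nitrogen elsewhere and bears on it only as a reminder that a single small change can move the read-out a long way. The expectation for compound 4 therefore rests on compound 2 alone, which gave "not active" (no number reported). A low inhibition is expected for compound 4, estimated at 15%, with a range from 0% to 45%, and a fair chance that the assay again reports no number.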

Compound 4, a percentage reported as inhibition, at one concentration (the size of the read-out at that concentration, not a potency): 21%
The estimate for compound 4 lay 6 percentage points below the measured number, within the range that was stated.
By their numbers in this assay, from the lowest: compound 4; then compound 3; then compound 1.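

No new step can be read: in this assay compound 2 is reported as "not active" (no number reported) and has no number to set against compound 4 at 21%. No measured evidence bears on this result. The compounds shown leave open how far amino in place of cyano moves inhibition on this core.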